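Alkoxy Replaces Carbamoyl on a Shared Ketone Core

This account rests on a few compounds, and the source may have more. Where it says the series, first, only, none or still open, it means among the compounds named here.

Compound 1, `CSc1coc(C(=O)CCCCCCc2ccccc2)n1`: in an assay on HEK-293T cells for inhibition of diacylglycerol lipase-alpha (Homo sapiens), read by colorimetric assay (a lower number here means a stronger inhibitor, a higher number a weaker inhibitor), compound 1 gives > 10000 nM, a limit of the assay.
Compound 2, `CS(=O)(=O)c1cnc(C(=O)CCCCCCc2ccccc2)o1`: in this assay compound 2 gives > 10000 nM, again a limit.
Compound 3, `CN(C)C(=O)c1cnc(C(=O)CCCCCCc2ccccc2)o1`: in this assay compound 3 gives > 10000 nM, also a limit.

Compound 3 therefore stands at no number at all in this assay but at a limit, and the two other values shown are limits as well, all three sitting at the limit of > 10000 nM in this assay, at which 3 of the 3 values shown sit. Among the compounds with values here, the only step that can be drawn among measured compounds, a step that the two limits leave unreadable from compound 2 to compound 3, is one that the two limits leave unreadable, so its size is not known.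

Compound 4, `COc1cnc(C(=O)CCCCCCc2ccccc2)o1`, differs from compound 3 by methoxy in place of dimethylcarbamoyl on an aromatic carbon. Within the data shown here, no measured step shows what this exchange does, and the step from compound 2 to compound 3 gives no size for comparison. Nothing in the values shown points away from the limit for this series, so no step beyond the scatter in either direction is expected in this assay; the step from compound 3 to compound 4 is estimated as a step that the limit leaves unreadable from compound 3 to compound 4. Compound 4 is accordingly expected to come out at 20000 nM, within 8000 nM to 60000 nM, most likely reported again only as a limit.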

Compound 4, half-maximal inhibitory concentration: > 10000 nM
Compound 4 gave a limit, no number (the forecaster's own chance of this, stated with the estimate: 85%); the middle value is on the limit's open side.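

In this assay compound 4 gives > 10000 nM, a limit and not a number. Within the data shown here, its steps from compound 1, compound 2 and compound 3 cannot be read, so no new step emerges, and all the values shown sit together: the limit of > 10000 nM in this assay, at which 4 of the 4 values shown sit. The compounds shown leave open how strongly any of them inhibits, and which group on the shared core, if any, would give a readable value.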